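A Fluorine for a Bromine on the Benzyl Arm

The source may hold more compounds than are shown below. What is called first, only, known or untested is meant among the compounds shown, and "the series" means these compounds.

Three measured compounds share one core and differ only in the group on a saturated chain carbon bound to an aromatic nitrogen. Compound 1 `O=C(/C=C/c1ccc(OCc2cn(Cc3ccccc3)nn2)cc1)c1ccc(Br)cc1` carries a plain phenyl there; in a functional assay on HepG2 cells (Homo sapiens) for inhibition, read by MTT assay, with a stated time of 48 h, tested at 10 uM (a higher number here means more inhibition of growth at the concentration tested, a lower number less inhibition of growth), compound 1 gives 22%. Compound 2 `O=C(/C=C/c1ccc(OCc2cn(Cc3cccc(Br)c3)nn2)cc1)c1ccc(Br)cc1` carries a 3-bromophenyl, and in this assay compound 2 gives 25%. Compound 3 `O=C(/C=C/c1ccc(OCc2cn(Cc3ccc(Br)cc3)nn2)cc1)c1ccc(Br)cc1` carries a 4-bromophenyl, and in this assay compound 3 gives 22%. Compound 3 thus stands level with compound 1, and compound 2 lies within the usual scatter of both. Every measured step is small: a number 3 percentage points higher from compound 1 to compound 2 (within the scatter), no change at the digits printed from compound 1 to compound 3 (within the scatter), and a number 3 percentage points lower from compound 2 to compound 3 (within the scatter).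

Compound 4 `O=C(/C=C/c1ccc(OCc2cn(Cc3ccccc3F)nn2)cc1)c1ccc(Br)cc1` differs from compound 3 by 2-fluorophenyl in place of 4-bromophenyl on a saturated chain carbon bound to an aromatic nitrogen. Among the compounds with values here, no measured step exchanges bromine for fluorine, so the steps above bear only loosely on this change. Adding a bromine, or placing it differently, produced nothing beyond the scatter. Compound 4 is expected to show a number 1 percentage points higher from compound 3 to compound 4 (within the scatter), nothing beyond the scatter. The estimate for compound 4 in this assay is 23%, with a range from 10% to 38%.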

Compound 4, percent growth inhibition at one concentration: 29%
Estimate against measurement, compound 4: 6 percentage points below; the measured number falls inside the stated range.
By their numbers in this assay, from the lowest: compounds 1, 3, 2 and 4 (each within the scatter of the next).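

In this assay the exchange of halogen on the benzyl arm proves as small as the earlier bromine steps: the result is a number 7 percentage points higher from compound 3 to compound 4 (within the scatter) and also a number 4 percentage points higher from compound 2 to compound 4 (within the scatter). Against the plain phenyl the picture holds, with a number 7 percentage points higher from compound 1 to compound 4 (within the scatter) and the phenyl, 3-bromophenyl, 4-bromophenyl and 2-fluorophenyl groups on this saturated chain carbon bound to an aromatic nitrogen all lying within the scatter of one another. Nothing shown explains these numbers or separates the effect of the element from that of its place on the ring.

Still open, going by these compounds, is whether an amine or a carboxylic acid on this phenyl ring, or a longer chain in place of the benzyl, would move the number beyond the scatter. Also open, on these data alone, is how these four compounds compare at other concentrations.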